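The source may report more compounds than this note shows. Statements on the series, on what has been measured and on what is new or still open speak of the compounds shown alone.

Measured so far:
Compound 1 `COc1cc(/C=N/c2c(C#N)ncn2-c2ccc(F)cc2)cc(OC)c1OC`: 8320 nM
Compound 2 `N#Cc1ncn(-c2ccc(F)cc2)c1/N=C/c1ccc([N+](=O)[O-])cc1`: 9100 nM

Both numbers come from a functional assay on MCF7 cells (Homo sapiens) for antiproliferative activity, read by MTT assay, with a stated time of 48 h; on this read-out lower numbers stand for stronger inhibition and higher numbers for weaker inhibition. In this assay compound 1 gives 8320 nM and compound 2 gives 9100 nM; these two values lie within the scatter of each other, so neither can be placed above or below the other. For the measured compounds named here, compound 2 therefore stands level with the only other measured compound, and no step between measured compounds is available to guide the next change.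

Compound 3 `N#Cc1ncn(-c2ccc(F)cc2)c1/N=C/c1ccc(O)cc1` keeps the shared core of compound 2 and differs in a single place: hydroxy in place of nitro on an aromatic carbon. Going by the values given here, with no measured step to lean on, the expectation rests on the fact that the two measured compounds, which differ in several places at once, still give numbers within the scatter of each other; one change at one position is therefore expected to move the number only a little, in either direction, and most likely by no more than the scatter. Compound 3 is accordingly estimated at 9000 nM, with a range from 3000 nM to 30000 nM, which means an expected step of a 1.0-fold lower number from compound 2 to compound 3 (0.00 log units; within the scatter) of essentially none beyond the scatter.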

Compound 3, half-maximal inhibitory concentration: 11500 nM
Compound 3: middle estimate off by 1.3-fold (0.11 log units), on the low side; the range from low to high includes it.
By their numbers in this assay, from the lowest: compounds 1, 2 and 3 (each within the scatter of the next).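

For the compounds shown here, this is the only step so far between two compounds that differ in just one place, so it gives the first direct view of this position on the aromatic ring, para to a large group. In this assay the exchange of nitro for hydroxy gives a 1.3-fold higher number from compound 2 to compound 3 (0.10 log units; within the scatter) and so does not separate the two compounds, even though the entering group has fewer heavy atoms and, unlike nitro, carries a hydrogen-bond donor. No outside measurement bears on this result, so it stands without an explanation.

Still open, on these data alone, is whether this position stays as undiscriminating with other groups: an amine or a carboxylic acid at the same place could stay level with compound 2 or could move beyond the scatter. Going by these compounds alone, also open is whether the same holds at other places on this ring or on the shared core, as the single readable step covers one exchange at one position.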